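This account rests on a few compounds, and the source may have more. Where it says the series, first, only, none or still open, it means among the compounds named here.

Compound 1, `COc1cc(CCc2cccc(F)c2)cc(OC)c1O`, carries a fluoro group on one of its two aromatic rings. Within the data shown here, in a functional assay on MKN-45 cells (Homo sapiens) for antiproliferative activity, read by MTT assay, with a stated time of 72 h (a higher number here means a weaker inhibitor, a lower number a stronger inhibitor), compound 1 gives 2970 nM, which is the second highest number among the three compounds measured so far. Its nearest neighbour is compound 3, `COc1ccc(CCc2ccccc2Cl)cc1OC`, which in this assay gives 2040 nM; the gap between these two numbers lies within the scatter of the assay, so they cannot be ranked against each other. The furthest is compound 2, `COc1cc(CCc2ccc(Cl)c(Cl)c2)cc(OC)c1O`, which in this assay gives 20600 nM, a gap from compound 1 that lies well beyond the scatter.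

Compound 4, `COc1cc(CCc2ccccc2)cc(OC)c1O`, has not yet been measured. It differs from compound 1 in one place only: hydrogen in place of fluoro on an aromatic carbon. Among the measured compounds shown here, no pair of measured compounds shows what this exact change does, so there is no measured step to lean on. Removing one small group from the outer ring while leaving the rest of the molecule untouched is the kind of change that often moves the number only a little. The step from compound 1 to compound 4 is therefore expected to be small, a 1.2-fold higher number from compound 1 to compound 4 (0.07 log units; within the scatter), and not clearly beyond the scatter in either direction. For compound 4 the expected value in this assay is 3500 nM, with a plausible range from 1500 nM to 8500 nM.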

Compound 4, half-maximal inhibitory concentration: 1040 nM
The estimate for compound 4 lay 3.4-fold (0.53 log units) above the measured number; measured number outside the range, below it.
By their numbers in this assay, from the lowest: compounds 4, 3 and 1 (each within the scatter of the next, the first and the last beyond it); then compound 2.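

Removing the fluoro group from the outer ring, at the carbon meta to a large group, gives in this assay a 2.9-fold lower number from compound 1 to compound 4 (0.46 log units; beyond the scatter), a modest change but one that clears the scatter. Among these compounds, this is the first measured step, and it shows that at this position, on this core, the unsubstituted ring with hydrogen gives the lower number, so the fluoro group is not a neutral passenger here. The finding holds for this one pair of compounds only, and nothing available here explains why the number moves.

Still open, going by these compounds, is whether another group on this same carbon, such as an amine, a carboxylic acid or a methyl group, would give a number closer to that of compound 1 or to that of compound 4. Also open, on these data alone, is whether a fluoro group on a different carbon of the outer ring would shift the number in the same direction, as compound 2 and compound 3 each differ from compound 4 in more than one place and cannot answer this.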